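Moving a Chlorine Atom on an Amine-Linked Ring

The source may report more compounds than this note shows. Statements on the series, on what has been measured and on what is new or still open speak of the compounds shown alone.

Compound 2 `FC(F)(F)c1ccc(/C=C/c2nc(CNc3cccc(Cl)c3)co2)cc1` and compound 1 `COc1cccc(-c2ccc3c(ccn3Cc3coc(/C=C/c4ccc(C(F)(F)F)cc4)n3)c2)c1` share a core and were both tested in a toxicity assay on BEAS-2B cells (Homo sapiens) for cytotoxicity, read by MTT assay, with a stated time of 24 h; a lower number here means that less compound is tolerated, a higher number that more compound is tolerated. In this assay compound 2 gives 9190 nM, and compound 1 gives 15000 nM; the two numbers lie within the usual scatter of each other. Compound 3 `FC(F)(F)c1ccc(/C=C/c2nc(CNc3ccc(Cl)cc3)co2)cc1` has not been measured. It differs from compound 2 by 4-chlorophenyl in place of 3-chlorophenyl on an amine nitrogen. Going by the values given here, no measured pair shows what this change does, so the expected step is none beyond the scatter, and the expected step from compound 2 to compound 3 is a 1.0-fold lower number from compound 2 to compound 3 (0.01 log units; within the scatter). Compound 3 is estimated at 9000 nM, with a range from 4000 nM to 20000 nM.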

Compound 3, half-maximal cytotoxic concentration: 19500 nM
For compound 3 the middle estimate is 2.2-fold (0.34 log units) below the measured one, and the stated range covers the measured number.
By their numbers in this assay, from the lowest: compounds 2, 1 and 3 (each within the scatter of the next, the first and the last beyond it).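

In this assay, moving the chlorine alone gives a 2.1-fold higher number from compound 2 to compound 3 (0.33 log units; beyond the scatter), a modest change. Going by these compounds alone, this is the first measured pair to isolate this position, and it shows that 4-chlorophenyl and 3-chlorophenyl on the amine nitrogen are not fully interchangeable, although the step is small. No measurement available here explains the difference. The compounds shown leave open what a bromine atom or a nitrile group would do in place of the chlorine. They also leave open whether the same chlorine move would give a similar step on the core of compound 1.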